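From Cyclopropylmethyl to Cyclohexyl on an Aromatic Oxygen

The compounds below may be only part of what the source reports. "The series", "measured", "known", "first", "only" and "open" are said of these compounds alone.

In a functional assay on NCI-H460 cells (Homo sapiens) for cytotoxicity, read by MTT assay, with a stated time of 96 h (on this read-out higher numbers stand for weaker inhibition and lower numbers for stronger inhibition), compound 1 `COc1ncc(-c2cc(OC)c3nc(N)nc(C)c3c2)cc1NS(=O)(=O)c1ccc(F)cc1F` gives 280 nM and compound 2 `COc1ncc(-c2cc(OCC3CC3)c3nc(N)nc(C)c3c2)cc1NS(=O)(=O)c1ccc(F)cc1F` gives 200 nM. Among the measured compounds shown here, these two values lie within the scatter of each other, so compound 2 stands level with the only other compound measured so far. The next compound, compound 3 `COc1ncc(-c2cc(OC3CCCCC3)c3nc(N)nc(C)c3c2)cc1NS(=O)(=O)c1ccc(F)cc1F`, differs from compound 2 by cyclohexyl in place of cyclopropylmethyl on an oxygen on an aromatic ring. For the measured compounds named here, one measured step bears on this, as it also alters the group on that oxygen: a 1.4-fold lower number from compound 1 to compound 2 (0.15 log units; within the scatter). Going by the values given here, with only that small step as a guide, no change beyond the scatter is expected in this assay, although no six-membered ring has yet been measured at this place. The expected change is a 1.3-fold higher number from compound 2 to compound 3 (0.10 log units; within the scatter). For compound 3 the estimate is 250 nM, with an expected range from 100 nM to 650 nM.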

Compound 3, half-maximal inhibitory concentration: 96 nM
The estimate for compound 3 lay 2.6-fold (0.42 log units) above the measured number; the measured number lies below the stated range.
By their numbers in this assay, from the lowest: compound 3; then compounds 2 and 1 (each within the scatter of the next).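

In this assay, the group on this oxygen now makes a difference that stands clear of the scatter: cyclohexyl in place of cyclopropylmethyl gives a 2.1-fold lower number from compound 2 to compound 3 (0.32 log units; beyond the scatter), and cyclohexyl in place of methyl gives a 2.9-fold lower number from compound 1 to compound 3 (0.46 log units; beyond the scatter). Among the compounds shown here, the earlier change from methyl to cyclopropylmethyl stayed within the scatter, so this is the first sign that the position responds to a change of group, although the effect is modest. No measurement at hand explains the lower number with cyclohexyl.

Cyclohexyl differs from cyclopropylmethyl in both ring size and the way the ring is joined to the oxygen, and these compounds cannot separate the two. A cyclohexylmethyl or cyclopentyl group would help to do so, while a piperidine ring would show whether a ring nitrogen is tolerated at this position.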